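A few compounds are considered here, and "the series" means these few. Any claim that something is new, unique, unknown or untested is made for them only; others in the source may bear on it.

Among the measured compounds shown here, compound 1 `CCCc1cc(N)c2cc(NC(=O)/C=C/c3ccc(O)cc3)ccc2n1` is one of three compounds measured in an assay on isolated protein for displacement of a labelled ligand from melanin-concentrating hormone receptor 1 (Homo sapiens) (on this read-out higher numbers stand for weaker inhibition and lower numbers for stronger inhibition), where compound 1 gives 1100 nM. Among the three numbers this is the second highest. Compound 3 `CCCc1cc(N)c2cc(NC(=O)CCc3ccccc3)ccc2n1` gives 8300 nM in this assay, a higher number that lies beyond the scatter; compound 2 `CCCc1cc(N2CCCC2)c2cc(NC(=O)/C=C/c3ccc(C(F)(F)F)cc3)ccc2n1` gives 17 nM in this assay, a lower number that also lies beyond the scatter. For the measured compounds named here, neither of these two compounds differs from compound 1 in a single place, so no step between measured compounds is available.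

Compound 4 `CCCc1cc(N)c2cc(NC(=O)/C=C/c3ccc(SC)cc3)ccc2n1` differs from compound 1 in one place: methylsulfanyl in place of hydroxy on an aromatic carbon. The hydroxy leaves the aromatic carbon para to the large group and a methylsulfanyl enters there, so the 4-hydroxyphenyl becomes a 4-(methylsulfanyl)phenyl.

Going by the values given here, no measured step of this kind exists among the three compounds, and the only compound without a hydroxy on that ring, compound 2, also carries other changes. Compound 4 is therefore expected to give a somewhat lower number than compound 1 in this assay, a step of a 2.4-fold lower number from compound 1 to compound 4 (0.39 log units; beyond the scatter) of modest size, with wide uncertainty. Compound 4 is estimated at 450 nM, within a range from 120 nM to 1700 nM.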

Compound 4, half-maximal inhibitory concentration: 9 nM
For compound 4 the middle estimate is 50-fold (1.70 log units) above the measured one; the whole stated range lies above it.
By their numbers in this assay, from the lowest: compounds 4 and 2 (each within the scatter of the next); then compound 1; then compound 3.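

Among the compounds shown here, the step of a 120-fold lower number from compound 1 to compound 4 (2.09 log units; beyond the scatter) in this assay is the first comparison in this set that ties a change in the number to one place alone. It shows that the group on the aromatic carbon para to a large group has a large influence on this read-out, and that replacing hydroxy with methylsulfanyl there is enough for that effect, with the rest of compound 1 left as it stands. The earlier compounds could not show this, since compound 2 also carries other changes and no measurement here explains the size of the step.

The change removes one hydrogen-bond donor and also brings in sulfur and an added carbon, so this single step cannot separate the contributions of those differences; methoxy, methyl or ethylsulfanyl at the same position would bear on that question. On these data alone, it also remains open whether the same replacement gives a step of similar size when the rest of the compound differs, as it does in compound 2 and compound 3.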